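The source may hold more compounds than are shown below. What is called first, only, known or untested is meant among the compounds shown, and "the series" means these compounds.

Measured so far in a functional assay on THP-1 cells (Homo sapiens) for inhibition, read by sulforhodamine B assay, with a stated time of 48 h, tested at 50 uM; a lower number here means less inhibition of growth, a higher number more inhibition of growth at the concentration tested:

Compound 1 `COc1cc(/C=C/C(=O)/C=C/c2ccccc2)ccc1OCc1cn(CCCCOc2cc(=O)oc3ccccc23)nn1`: 36%
Compound 2 `COc1ccc(/C=C/C(=O)/C=C/c2ccc(OCc3cn(CCCCCOc4cc(=O)oc5ccccc45)nn3)c(OC)c2)cc1`: 39%
Compound 3 `COc1cccc(/C=C/C(=O)/C=C/c2ccc(OCc3cn(CCCOc4cc(=O)oc5ccccc45)nn3)c(OC)c2)c1`: 58%

Compound 1, at 36%, lies within the usual scatter of compound 2, at 39%. Compound 3, at 58%, stands higher than compound 1 by more than the scatter, so compound 1 sits in the lower part of this small set.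

Compound 4 `COc1ccccc1/C=C/C(=O)/C=C/c1ccc(OCc2cn(CCCCOc3cc(=O)oc4ccccc34)nn2)c(OC)c1` differs from compound 1 in a single place: methoxy in place of hydrogen on an aromatic carbon. Here methoxy takes the place of hydrogen on an aromatic carbon, ortho to a large group, so that phenyl becomes 2-methoxyphenyl.

Among the measured compounds shown here, no two measured compounds differ in only one place, so the data hold no direct measure of what such a change does in this assay. With so little to go on, the expectation is a small upward shift at most, probably none beyond the scatter. The expected size of the change is a number 6 percentage points higher from compound 1 to compound 4 (within the scatter). The range stays wide on the upper side, since compound 3 reaches 58%. For compound 4 the estimated value is 42%, with an expected range from 28% to 58%.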

Compound 4, percent growth inhibition at one concentration: 40%
For compound 4 the middle estimate is 2 percentage points above the measured one; measured number inside the range.
By their numbers in this assay, from the lowest: compounds 1, 2 and 4 (each within the scatter of the next); then compound 3.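

Putting methoxy in place of hydrogen on an aromatic carbon, ortho to a large group, turns phenyl into 2-methoxyphenyl and gives, in this assay, a number 4 percentage points higher from compound 1 to compound 4 (within the scatter). Among the compounds shown here, this is the first direct measure of a single change, and it shows that adding this group at this position does not detectably alter growth inhibition at the concentration tested, so the position can carry a methoxy group without a measurable loss. Nothing in the available data explains this result.

From the compounds shown here alone, it remains open whether a different group on the same carbon, such as an amine, a carboxylic acid or a fluorine atom, would move the number beyond the scatter. Also open, going by these compounds, is whether methoxy on another carbon of this ring would behave as it does here.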